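The source may hold more compounds than are shown below. What is called first, only, known or untested is meant among the compounds shown, and "the series" means these compounds.

In a functional assay on U-937 cells (Homo sapiens) for inhibition, read by MTT assay, with a stated time of 24 h (on this read-out higher numbers stand for weaker inhibition of growth and lower numbers for stronger inhibition of growth), compound 1 `Cc1cn(-c2cc(C(=O)Nc3ccc(C4=Nc5cnn(Cc6ccccc6)c5NC(=O)C4)cc3)cc(C(F)(F)F)c2)cn1` reached only a limit, > 30000 nM. Compound 2 `COc1ccc(Cn2ncc3c2NC(=O)CC(c2ccc(NC(=O)Nc4ccc(Cl)c(C(F)(F)F)c4)cc2)=N3)cc1` gave 7290 nM. Compound 3 `COc1ccc(Cn2ncc3c2NC(=O)CC(c2cccc(NC(=O)Nc4cccc(Cl)c4)c2)=N3)cc1` gave 630 nM, the lower of the two actual numbers, and its gap to compound 2 lies beyond the scatter. Compound 4 `COc1ccc(Cn2ncc3c2NC(=O)CC(c2cccc(NC(=O)Nc4ccc(Cl)cc4)c2)=N3)cc1` has not yet been measured. It carries 4-chlorophenyl in place of the 3-chlorophenyl of compound 3 on an amide-type nitrogen (4-chlorophenyl in place of 3-chlorophenyl on an amide-type nitrogen). Within the data shown here, no measured pair shows this change alone, so only a loose expectation is possible. Compound 3 at 630 nM anchors it, while compound 2 at 7290 nM pulls it towards weaker inhibition of growth. The expected change is modest, a 1.7-fold higher number from compound 3 to compound 4 (0.24 log units; within the scatter). For compound 4 the estimated value is 1100 nM, with an expected range of 350 nM to 4000 nM.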

Compound 4, concentration for 50% growth inhibition: 580 nM
Estimate against measurement, compound 4: 1.9-fold (0.28 log units) above; the range from low to high includes it.
By their numbers in this assay, from the lowest: compounds 4 and 3 (each within the scatter of the next); then compound 2. At a limit, above all of these: compound 1.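

In this assay, 4-chlorophenyl in place of 3-chlorophenyl on an amide-type nitrogen gives a 1.1-fold lower number from compound 3 to compound 4 (0.04 log units; within the scatter), so the two chlorophenyl groups cannot be told apart at this place. Among these compounds, this is the first single change that can be read in the set, and it alters only where the chlorine sits on that ring. Nothing measured here offers a reason for this outcome. As far as these compounds go, it remains open whether an unsubstituted phenyl or a cyclohexyl on that nitrogen would give a similar number. Also open, from the compounds shown here alone, is what an amine or a carboxylic acid on that ring would do.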